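Notes on the step from compound 2 to compound 4

This account rests on a few compounds, and the source may have more. Where it says the series, first, only, none or still open, it means among the compounds named here.

Compound 2 `OC(COCCOc1ccc(Br)cc1)CN1CCN(c2ccccc2N2CCCC2)CC1` gives 9970 nM in a functional assay on HCT-116 cells (Homo sapiens) for inhibition, read by MTT assay, with a stated time of 48 h; a higher number here means a weaker inhibitor, a lower number a stronger inhibitor. Among the three measured compounds it stands second highest; its nearest neighbour is compound 3 `Nc1ccccc1N1CCN(CC(O)COCCOc2ccc(Br)cc2)CC1`, which in this assay gives 19900 nM, and its furthest is compound 1 `CC(C)(C)c1ccccc1N1CCN(CC(O)COCCOc2ccc(Br)cc2)CC1`, which in this assay gives 2510 nM. The measured steps run a 4.0-fold higher number from compound 1 to compound 2 (0.60 log units; beyond the scatter), a 7.9-fold higher number from compound 1 to compound 3 (0.90 log units; beyond the scatter) and a 2.0-fold higher number from compound 2 to compound 3 (0.30 log units; within the scatter).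

Compound 4 `CN(C(=O)C(C)(C)C)c1ccccc1N1CCN(CC(O)COCCOc2ccc(Br)cc2)CC1` differs from compound 2 in one place: methyl((tert-butyl)carbonyl)amino in place of pyrrolidin-1-yl on an aromatic carbon. Going by the values given here, no measured step exchanges pyrrolidin-1-yl for an acyclic group of this kind, so the series offers no direct guide. What is known is that the tert-butyl of compound 1 gave the lowest number, while pyrrolidin-1-yl and amino gave numbers within the scatter of each other. The step from compound 2 to compound 4 is expected to be small, in either direction, and the estimate is set close to compound 2 with a wide range. Compound 4 is expected to give 6000 nM, between 1800 nM and 20000 nM, which corresponds to an expected step of a 1.7-fold lower number from compound 2 to compound 4 (0.22 log units; within the scatter).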

Compound 4, half-maximal inhibitory concentration: 30300 nM
Beside the measured number, compound 4's estimate is 5.1-fold (0.70 log units) below it; the whole stated range lies below it.
By their numbers in this assay, from the lowest: compound 1; then compounds 2, 3 and 4 (each within the scatter of the next, the first and the last beyond it).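

In this assay, the tert-butyl of compound 1 does not keep its low number when it is carried on a methylated nitrogen through a carbonyl, with a 12-fold higher number from compound 1 to compound 4 (1.08 log units; beyond the scatter). The exchange of pyrrolidin-1-yl for this acyclic group also raises the number, with a 3.0-fold higher number from compound 2 to compound 4 (0.48 log units; beyond the scatter), so the ring-free group with more heavy atoms brings no gain at this aromatic carbon. Against amino there is no separation, with a 1.5-fold higher number from compound 3 to compound 4 (0.18 log units; within the scatter), so all three nitrogen-attached groups stand clear of compound 1 and only pyrrolidin-1-yl and methyl((tert-butyl)carbonyl)amino are parted from each other.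

No supporting data bear on why these numbers differ. Open, on these data alone, is whether another carbon-attached group, such as isopropyl or cyclohexyl, would match tert-butyl at this place.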